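Benzothiazole-aryl sulfonamides: urea in place of cyclopropyl

The source may report more compounds than this note shows. Statements on the series, on what has been measured and on what is new or still open speak of the compounds shown alone.

Working notes on three measured compounds and one to come. The shared core is seen in compound 1 `COc1ncc(-c2ccc3nc(NC4CC4)sc3c2)cc1NS(=O)(=O)c1ccc(F)cc1`, which in a functional assay on HCT-116 cells (Homo sapiens) for antiproliferative activity, read by MTT assay, with a stated time of 72 h (on this read-out lower numbers stand for stronger inhibition and higher numbers for weaker inhibition), gives 1560 nM. Compound 2 `CCN(CC)CCNC(=O)Nc1nc2ccc(-c3cnc(OC)c(NS(=O)(=O)c4ccc(C)cc4)c3)cc2s1` gives 180 nM in this assay. Compound 3 `CCCNc1nc2ccc(-c3cnc(Cl)c(NS(=O)(=O)c4ccc(F)cc4)c3)cc2s1` gives > 20000 nM, a limit of the assay and not a number; this is the limit of > 20000 nM in this assay, at which 1 of the 3 values shown sits. Among the two numbers, compound 1 stands highest; compound 2 sits at the lower number, a gap beyond the scatter.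

Compound 4 `COc1ncc(-c2ccc3nc(NC(=O)NCCN4CCN(C)CC4)sc3c2)cc1NS(=O)(=O)c1ccc(F)cc1` is not yet measured. Its change from compound 1 is (2-(4-methylpiperazin-1-yl)ethyl)carbamoyl in place of cyclopropyl on a nitrogen on an aromatic ring. Compound 2 also bears a carbamoyl group on a nitrogen on an aromatic ring, and gives 180 nM; on that basis a step downward, beyond the scatter, is expected. The step of a 5.2-fold lower number from compound 1 to compound 4 (0.72 log units; beyond the scatter) is the expected size of that move in this assay. Compound 4 is estimated at 300 nM, with a range from 80 nM to 1200 nM.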

Compound 4, half-maximal inhibitory concentration: 540 nM
For compound 4 the middle estimate is 1.8-fold (0.26 log units) below the measured one; low and high end bracket the measured number.
By their numbers in this assay, from the lowest: compound 2; then compound 4; then compound 1. At a limit, above all of these: compound 3.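

In this assay the series now has its first comparison of two compounds that differ in one place, a 2.9-fold lower number from compound 1 to compound 4 (0.46 log units; beyond the scatter). On a nitrogen on an aromatic ring, cyclopropyl can thus give way to the much larger (2-(4-methylpiperazin-1-yl)ethyl)carbamoyl with a modest gain, and the activity of the core of compound 1 is kept rather than lost. Nothing measured here accounts for the size or direction of this step.

A single step cannot show whether the carbamoyl or the 4-methylpiperazine part carries the change. An acetyl on the same nitrogen, or a morpholine ring in place of the 4-methylpiperazine, would separate the two contributions.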